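This account rests on a few compounds, and the source may have more. Where it says the series, first, only, none or still open, it means among the compounds named here.

Compound 3 `O=C(CN(c1ncnc2c1ncn2C1CCCCO1)C1CC1)NCC(=O)OCc1ccccc1` stands lowest of the three compounds measured in a functional assay on the whole organism (Tail, strain ICR) with Mus musculus as the target, in the tail flick test, with a stated time of 120 min, at a dose of 25 umol/kg by the oral route (on this read-out lower numbers stand for a weaker effect and higher numbers for a stronger effect at the one dose given), where compound 3 gives 17.2%. Compound 2 `C[C@H](NC(=O)CN(c1ncnc2c1ncn2C1CCCCO1)C1CC1)C(=O)OCc1ccccc1` gives 25.3%, and compound 1 `O=C(CN(c1ncnc2c1ncn2C1CCCCO1)C1CC1)N[C@@H](CO)C(=O)OCc1ccccc1` gives 29.2%. The step of a number 8.1 percentage points lower from compound 2 to compound 3 (within the scatter), whereas the step of a number 12 percentage points lower from compound 1 to compound 3 (beyond the scatter). Compound 4 `CC(C)C[C@H](NC(=O)CN(c1ncnc2c1ncn2C1CCCCO1)C1CC1)C(=O)OCc1ccccc1` differs from compound 3 by isobutyl in place of hydrogen on a saturated chain carbon bound to an amide-type nitrogen and a carbonyl carbon. Going by the values given here, both measured steps took a group away from this same carbon, and only the loss of hydroxymethyl moved the number beyond the scatter; no measured step involves an isobutyl, so the size of this change is uncertain. A small rise in this assay is expected for compound 4, with an estimated a number 8.8 percentage points higher from compound 3 to compound 4 (within the scatter). Compound 4 is therefore estimated at 26%, in a range from 12% to 40%.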

Compound 4, a percentage reported as activity, at one dose (the size of the read-out at that dose, not a potency): 12.8%
Beside the measured number, compound 4's estimate is 13.2 percentage points above it; measured number inside the range.
By their numbers in this assay, from the lowest: compounds 4, 3, 2 and 1 (each within the scatter of the next, the first and the last beyond it).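

Isobutyl in place of hydrogen on this saturated chain carbon gives a number 4.4 percentage points lower from compound 3 to compound 4 (within the scatter) in this assay, so this added chain lifts the number no higher than hydrogen does. Compared with the other two groups on this carbon, the steps are a number 12.5 percentage points lower from compound 2 to compound 4 (beyond the scatter) and a number 16.4 percentage points lower from compound 1 to compound 4 (beyond the scatter), so isobutyl brings no gain over methyl or hydroxymethyl. Nothing available explains this result. Going by these compounds, what an amine or a carboxylic acid on this carbon would give stays open, as does whether these differences hold at other doses or times.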